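This account rests on a few compounds, and the source may have more. Where it says the series, first, only, none or still open, it means among the compounds named here.

Measured so far:
compound 1 `O=c1[nH]cnc2c1c(-c1ccsc1)cn2[C@@H]1O[C@H](CO)[C@@H](O)[C@H]1O`: > 100000 nM (a limit)
compound 2 `O=c1[nH]cnc2c1c(-c1cc3ccccc3o1)cn2[C@@H]1O[C@H](CO)[C@@H](O)[C@H]1O`: > 100000 nM (a limit)
compound 3 `Cc1nc(N)c2c(-c3cc4ccccc4o3)cn([C@@H]3O[C@H](CO)[C@@H](O)[C@H]3O)c2n1`: 91800 nM

In an ADME assay on MRC5 cells (Homo sapiens), read by MTT assay, with a stated time of 72 h (a lower number here means a stronger inhibitor, a higher number a weaker inhibitor), compound 1 returns only a limit, > 100000 nM. Compound 2 likewise returns only a limit, > 100000 nM. Going by the values given here, compound 3 is the one compound with a number, giving 91800 nM. The change from compound 2 to compound 1 is thiophen-3-yl in place of 1-benzofuran-2-yl on an aromatic carbon; its step that the two limits leave unreadable from compound 2 to compound 1 cannot be read because both ends sit at the limit of > 100000 nM in this assay, at which 2 of the 3 values shown sit. How the core of compound 3 differs from that of compound 2 is not broken down here. Compound 4 `Cc1nc(N)c2c(-c3ccsc3)cn([C@@H]3O[C@H](CO)[C@@H](O)[C@H]3O)c2n1` carries the same change on the core of compound 3: thiophen-3-yl in place of 1-benzofuran-2-yl on an aromatic carbon. Given that the step that the two limits leave unreadable from compound 2 to compound 1 is unreadable and compound 3 gives a weak number at 91800 nM, the expected step is a 1.3-fold higher number from compound 3 to compound 4 (0.12 log units; within the scatter). Compound 4 is therefore estimated at 120000 nM, likely between 45000 nM and 320000 nM, with a strong chance that only a limit is returned.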

Compound 4, half-maximal inhibitory concentration: > 100000 nM
Compound 4 was reported as a limit (the forecaster's own chance of this, stated with the estimate: 70%); the middle value lies beyond the limit too.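

In this assay, thiophen-3-yl in place of 1-benzofuran-2-yl on the core of compound 3 gives an at least 1.0-fold higher number from compound 3 to compound 4 (0.03 log units; that floor lies within the scatter). Compound 4 returns only a limit, > 100000 nM. The step therefore has a floor but no measured size, and the same change from compound 2 to compound 1 cannot be read, so carry-over between the two cores is neither shown nor ruled out, because most values sit at one ceiling: the limit of > 100000 nM in this assay, at which 3 of the 4 values shown sit.

Open, from the compounds shown here alone, is whether a different group on this aromatic carbon, such as an aminomethyl group, a carboxylic acid or a longer alkyl chain, would give a number on either core. A pair of such numbers would allow the step to be compared between cores.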